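This account rests on a few compounds, and the source may have more. Where it says the series, first, only, none or still open, it means among the compounds named here.

Measured so far in a functional assay on HEK293 cells for agonist activity at D(4) dopamine receptor (Homo sapiens), read by FLIPR; on this read-out lower numbers stand for an effect already at smaller amounts and higher numbers for an effect only at larger amounts of compound:
compound 1, `CCc1cccc(NC(=O)CN2CCC(c3cccc[n+]3[O-])CC2)c1`: 95 nM
compound 2, `O=C(CN1CCC(c2cccc[n+]2[O-])CC1)Nc1cccc(F)c1`: 160 nM
compound 3, `O=C(CN1CCC(c2cccc[n+]2[O-])CC1)Nc1ccc(F)cc1`: 85 nM

Compound 3 gives the lowest of these three numbers in this assay, yet it is not set apart: the step of a 1.1-fold lower number from compound 1 to compound 3 (0.05 log units; within the scatter) and the step of a 1.9-fold lower number from compound 2 to compound 3 (0.27 log units; within the scatter) both stay inside the usual scatter, so the three compounds read as one group.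

Compound 4, `Cc1cc(F)ccc1NC(=O)CN1CCC(c2cccc[n+]2[O-])CC1`, follows from compound 3 by one change: methyl in place of hydrogen on an aromatic carbon. Going by the values given here, no measured step touches this kind of change. The steps known so far concern the substituent on the phenyl ring attached to the amide nitrogen and its position — a 1.7-fold higher number from compound 1 to compound 2 (0.23 log units; within the scatter) and a 1.9-fold lower number from compound 2 to compound 3 (0.27 log units; within the scatter) — and each of them stayed within the scatter. On that record, a small added group on this ring is not expected to move the number far. The estimate for compound 4 is therefore a step of a 1.2-fold higher number from compound 3 to compound 4 (0.07 log units; within the scatter), which means no change beyond the scatter is expected.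

Compound 4 is thus estimated at 100 nM, with a range from 40 nM to 250 nM.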

Compound 4, half-maximal effective concentration: 60 nM
Compound 4: the middle estimate sits 1.7-fold (0.22 log units) above what was measured, within the range that was stated.
By their numbers in this assay, from the lowest: compounds 4, 3, 1 and 2 (each within the scatter of the next, the first and the last beyond it).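

In this assay, a methyl on the aromatic carbon ortho to a large group and meta to the fluoro group is tolerated: a 1.4-fold lower number from compound 3 to compound 4 (0.15 log units; within the scatter) stays within the scatter, and so does a 1.6-fold lower number from compound 1 to compound 4 (0.20 log units; within the scatter). The 4-fluoro-2-methylphenyl group also gives the first step beyond the scatter among these compounds, a 2.7-fold lower number from compound 2 to compound 4 (0.43 log units; beyond the scatter), although this step is modest and is seen only against the 3-fluorophenyl group. No evidence is available that bears on this result.

The compounds shown leave open whether this position accepts groups other than methyl, such as a methoxy group, an amine or a longer chain. They also leave open whether the methyl would read the same on a ring without the fluoro group.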